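The source may report more compounds than this note shows. Statements on the series, on what has been measured and on what is new or still open speak of the compounds shown alone.

Compound 1 `N=C(NS(=O)(=O)c1ccccc1Cl)N1CCN(c2cc3c(cc2F)c(=O)c(C(=O)O)cn3C2CC2)CC1`: 32 nM
Compound 2 `Cc1ccc(S(=O)(=O)NC(=N)N2CCN(c3cc4c(cc3F)c(=O)c(C(=O)O)cn4C3CC3)CC2)cc1`: 32 nM
Compound 3 `CCn1cc(C(=O)O)c(=O)c2cc(F)c(N3CCN(C(=N)NS(=O)(=O)c4ccccc4C(F)(F)F)CC3)cc21`: 32 nM

All three were measured in a functional assay on HeLa cells (Homo sapiens) for antiproliferative activity, read by MTT assay, with a stated time of 72 h; a lower number here means a stronger inhibitor, a higher number a weaker inhibitor. Compound 1 gives 32 nM, compound 2 gives 32 nM and compound 3 gives 32 nM, so compound 1 stands level with both of the others at the digits shown and none of the three can be called stronger or weaker. Within the data shown here, the one step that is fully defined, from compound 1 to compound 2, reads no change at the digits printed from compound 1 to compound 2 (within the scatter): putting 4-methylphenyl in place of 2-chlorophenyl on the sulfonyl sulfur left the reading unchanged within the scatter.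

Compound 4 `N=C(NS(=O)(=O)c1ccccc1C(F)(F)F)N1CCN(c2cc3c(cc2F)c(=O)c(C(=O)O)cn3C2CC2)CC1` differs from compound 1 in a single place: trifluoromethyl in place of chloro on an aromatic carbon. Among the measured compounds shown here, compound 3 carries the same trifluoromethyl-bearing ring on its sulfonyl sulfur but differs from compound 4 elsewhere on the shared core, so no single step links it to compound 1 or compound 4; all that its value shows is that a ring of this kind is compatible with a reading level with compound 1. Since changing the group on this ring from compound 1 to compound 2 moved nothing, the expectation for compound 4 is a step of no change at the digits printed from compound 1 to compound 4 (within the scatter), that is, none beyond the scatter. Compound 4 is therefore estimated at 32 nM, with a range from 16 nM to 64 nM.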

Compound 4, half-maximal inhibitory concentration: 32 nM
The estimate for compound 4 equals the measured number at the digits printed; the range from low to high includes it.
By their numbers in this assay, from the lowest: compounds 1, 2, 3 and 4 (each within the scatter of the next).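

In this assay, the step of no change at the digits printed from compound 1 to compound 4 (within the scatter) comes with trifluoromethyl, a group of more heavy atoms, entering where chloro left, so this aromatic carbon accepts either group with no reading beyond the scatter. The ring on the sulfonyl sulfur now has a second single change behind it, since the step of no change at the digits printed from compound 2 to compound 4 (within the scatter) comes with 2-(trifluoromethyl)phenyl in place of 4-methylphenyl, and this change also stays within the scatter. Among these compounds, the aromatic nitrogen is read through a single change for the first time, and the step of no change at the digits printed from compound 3 to compound 4 (within the scatter) shows that cyclopropyl in place of ethyl likewise stays within the scatter.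

It remains open whether an amine or a hydroxyl on this aromatic carbon, or a longer chain such as butyl on the aromatic nitrogen, would move the reading at all, as every change shown so far leaves it within the scatter. Nothing available explains why these changes leave the reading where it is.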